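The source may report more compounds than this note shows. Statements on the series, on what has been measured and on what is new or still open speak of the compounds shown alone.

Two members of the series have been measured in a functional assay on HEp-2 cells (Homo sapiens) for cytotoxicity, read by MTT assay, with a stated time of 72 h, tested at 2.5 ug/mL; a higher number here means more inhibition of growth at the concentration tested, a lower number less inhibition of growth. Compound 1 `O=C1NC(=S)/C(=C/c2cccc(Cl)c2)S1` gives 5.44% and stands highest of the two numbers. Within the data shown here, compound 2 `O=C1NC(=S)/C(=C/c2ccccc2Cl)S1` gives -11.5%, a number lower than that of compound 1 by a gap beyond the scatter; no step between the two is counted. Compound 3 `O=C1NC(=S)/C(=C/c2cccc(F)c2)S1` is not yet measured; it differs from compound 1 by fluoro in place of chloro on an aromatic carbon. With one measured value behind it, the step is expected to be small, a number 3.4 percentage points lower from compound 1 to compound 3 (within the scatter), not beyond the scatter in this assay. For compound 3 the expected value in this assay is 2%, with a range from -12% to 16%.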

Compound 3, percent growth inhibition at one concentration: 7.03%
Compound 3: middle estimate off by 5 percentage points, on the low side; low and high end bracket the measured number.
By their numbers in this assay, from the lowest: compound 2; then compounds 1 and 3 (each within the scatter of the next).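

In this assay fluoro in place of chloro on this aromatic carbon gives a number 1.6 percentage points higher from compound 1 to compound 3 (within the scatter) and so does not separate the two compounds. Among these compounds, this is the first single-place step, and it shows that this position tolerates either group without a change beyond the scatter. Nothing measured here accounts for the size of this step.

As far as these compounds go, whether an amine, a carboxylic acid or a methoxy group on this carbon would move the number beyond the scatter remains open. Also open, from the compounds shown here alone, is how fluoro reads on the other aromatic carbons.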